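The source may report more compounds than this note shows. Statements on the series, on what has been measured and on what is new or still open speak of the compounds shown alone.

The measured compounds and their numbers in an assay on HEK293 cells for displacement of a labelled ligand from 5-hydroxytryptamine receptor 7 (Rattus norvegicus), read by radioligand binding (on this read-out higher numbers stand for weaker inhibition and lower numbers for stronger inhibition), are: compound 1 `CCn1nc2c(c1-c1ccccc1)CCNCC2` gives 140 nM; compound 2 `CC(C)(C)n1nc2c(c1-c1ccccc1)CCNCC2` gives 30 nM; compound 3 `c1ccc(-c2c3c(nn2C2CC2)CCNCC3)cc1` gives 20 nM.

Compound 2 stands second highest of these three. Its nearest neighbour is compound 3, with a 1.5-fold lower number from compound 2 to compound 3 (0.18 log units; within the scatter), and its furthest is compound 1, with a 4.7-fold lower number from compound 1 to compound 2 (0.67 log units; beyond the scatter). Compound 4 `c1ccc(-c2c3c(nn2C2CCC2)CCNCC3)cc1` differs from compound 2 by cyclobutyl in place of tert-butyl on an aromatic nitrogen. Within the data shown here, two steps bear on this change: the step of a 4.7-fold lower number from compound 1 to compound 2 (0.67 log units; beyond the scatter) and the step of a 7.0-fold lower number from compound 1 to compound 3 (0.85 log units; beyond the scatter), both branched groups in this place giving lower numbers than ethyl, and the step of a 1.5-fold lower number from compound 2 to compound 3 (0.18 log units; within the scatter) between the two branched groups lies within the scatter. A step from compound 2 to compound 4 is therefore expected to be small, a 1.4-fold lower number from compound 2 to compound 4 (0.13 log units; within the scatter), and not beyond the scatter. Compound 4 is estimated at 22 nM, with a range from 10 nM to 50 nM.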

Compound 4, inhibition constant: 90 nM
Compound 4: the middle estimate sits 4.1-fold (0.61 log units) below what was measured; measured number outside the range, above it.
By their numbers in this assay, from the lowest: compounds 3 and 2 (each within the scatter of the next); then compounds 4 and 1 (each within the scatter of the next).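

In this assay, among these compounds, the group on the aromatic nitrogen proves more selective than the earlier compounds suggested. Cyclobutyl has the same heavy-atom count as tert-butyl, yet replacing tert-butyl with it gives (a 3.0-fold higher number from compound 2 to compound 4 (0.48 log units; beyond the scatter)), and replacing cyclopropyl with it gives (a 4.5-fold higher number from compound 3 to compound 4 (0.65 log units; beyond the scatter)). Replacing ethyl with cyclobutyl gives only (a 1.6-fold lower number from compound 1 to compound 4 (0.19 log units; within the scatter)), so a ring at this place does not by itself secure the low numbers, as compound 4 shows. No measurement here accounts for this difference. As far as these compounds go, whether isopropyl or cyclopentyl would track cyclopropyl or cyclobutyl remains open.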